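Trimming Benzamido to Formyl on the Aryl Triazole

The source may hold more compounds than are shown below. What is called first, only, known or untested is meant among the compounds shown, and "the series" means these compounds.

Measured compounds:
- compound 1 `COc1cc(/C=C/C(C)=O)ccc1OCc1cn(-c2ccccc2OC)nn1`: 29100 nM
- compound 2 `COc1cc(/C=C/C(C)=O)ccc1OCc1cn(-c2ccc(NC(=O)c3ccccc3)cc2)nn1`: 86700 nM

Of the compounds shown here, two have been measured in a functional assay on MCF7 cells (Homo sapiens) for antiproliferative activity, read by MTT assay, with a stated time of 48 h; on this read-out higher numbers stand for weaker inhibition and lower numbers for stronger inhibition. Compound 1 `COc1cc(/C=C/C(C)=O)ccc1OCc1cn(-c2ccccc2OC)nn1` gives 29100 nM, while compound 2 `COc1cc(/C=C/C(C)=O)ccc1OCc1cn(-c2ccc(NC(=O)c3ccccc3)cc2)nn1` gives 86700 nM, the higher of the two numbers, and its gap to compound 1 lies beyond the usual scatter. Compound 3 `COc1cc(/C=C/C(C)=O)ccc1OCc1cn(-c2ccc(C=O)cc2)nn1` differs from compound 2 in one place: formyl in place of benzamido on an aromatic carbon. Going by the values given here, no measured pair shows this exact change, so its effect is open. A modest move toward a lower number is expected, a 2.2-fold lower number from compound 2 to compound 3 (0.34 log units; beyond the scatter). Compound 1 carries a smaller substituent on that ring and gives 29100 nM, which points the same way. Compound 3 is estimated at 40000 nM, within 15000 nM to 110000 nM.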

Compound 3, half-maximal inhibitory concentration: 86400 nM
The estimate for compound 3 lay 2.2-fold (0.33 log units) below the measured number; the range from low to high includes it.
By their numbers in this assay, from the lowest: compound 1; then compounds 3 and 2 (each within the scatter of the next).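

In this assay, trimming benzamido to formyl on this aromatic carbon, para to a large group, leaves the number unchanged within the scatter (a 1.0-fold lower number from compound 2 to compound 3 (0.00 log units; within the scatter)). The size of this substituent therefore makes no visible difference across this pair, whereas 4-formylphenyl in place of 2-methoxyphenyl on the aromatic nitrogen gives a gap beyond the scatter (a 3.0-fold higher number from compound 1 to compound 3 (0.47 log units; beyond the scatter)). No data here explain either result.

As far as these compounds go, whether an amine or a carboxylic acid on that aromatic carbon would move the number stays open. So does whether the gap between compound 1 and compound 3 comes from the group itself or from where it sits on the ring.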